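The source may report more compounds than this note shows. Statements on the series, on what has been measured and on what is new or still open speak of the compounds shown alone.

Of the compounds shown here, three built on a shared core have been measured in a functional assay on NCI-H226 cells (Homo sapiens) for inhibition, read by MTT assay, with a stated time of 48 h, tested at 10 uM; a lower number here means less inhibition, a higher number more inhibition at the concentration tested (going by the name of the read-out). Compound 1 `COc1cc(NC(=O)Nc2cc(Nc3ccc(OC)c(C)c3)ncn2)cc(OC)c1` gives 39.7% in this assay. Compound 2 `COc1cc(Br)ccc1Nc1cc(NC(=O)Nc2c(Cl)cccc2Cl)ncn1` gives 43% in this assay, and compound 3 `COc1ccc(F)cc1Nc1cc(NC(=O)Nc2c(Cl)cccc2Cl)ncn1` gives 31.3%. Among these three numbers compound 1 stands second highest; its gap to compound 2 and its gap to compound 3 both lie within the usual scatter, so no order can be read among the three. Among the measured compounds shown here, the only step in which just one part of the molecule changes is a number 11.7 percentage points lower from compound 2 to compound 3 (beyond the scatter), a modest drop that comes from putting one group in place of another on a nitrogen on an aromatic ring.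

Compound 4 `CCc1cccc(Nc2cc(NC(=O)Nc3cc(OC)cc(OC)c3)ncn2)c1` has not yet been measured. It differs from compound 1 in one place: 3-ethylphenyl in place of 4-methoxy-3-methylphenyl on a nitrogen on an aromatic ring. This change again sits on a nitrogen on an aromatic ring, so the step from compound 2 to compound 3 is the nearest guide, but it swaps different groups and cannot fix the direction. For the measured compounds named here, with only one modest step to go by, nothing beyond the scatter is expected. Compound 4 is therefore expected to give 36% in this assay, within 20% to 52%. That estimate amounts to an expected a number 3.7 percentage points lower from compound 1 to compound 4 (within the scatter).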

Compound 4, a percentage reported as inhibition, at one concentration (the size of the read-out at that concentration, not a potency): 36.7%
For compound 4 the middle estimate is 0.7 percentage points below the measured one; measured number inside the range.
By their numbers in this assay, from the lowest: compounds 3, 4, 1 and 2 (each within the scatter of the next, the first and the last beyond it).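

Putting 3-ethylphenyl in place of 4-methoxy-3-methylphenyl on this nitrogen gives a number 3 percentage points lower from compound 1 to compound 4 (within the scatter) in this assay and so shows that, with the rest of compound 1 held fixed, this swap does not move the read-out measurably. Among the compounds shown here, the leaving group carries a hydrogen-bond acceptor and the entering group carries none, yet the two compounds cannot be told apart here, whereas the only earlier step at this place, a number 11.7 percentage points lower from compound 2 to compound 3 (beyond the scatter) on a different partner at the other end of the molecule, did exceed the scatter. Nothing available explains why this swap leaves the number within the scatter.

Still open, from the compounds shown here alone, is whether a group of a different kind on this phenyl ring, such as an amine or a carboxylic acid, would change the inhibition beyond the scatter. For the compounds shown here, also unsettled is whether the result for this swap would hold with the 2,6-dichlorophenyl group of compound 2 at the far end, and a reading at one concentration gives no potency for either compound.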